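The compounds below may be only part of what the source reports. "The series", "measured", "known", "first", "only" and "open" are said of these compounds alone.

Measured compounds:
compound 1, `COc1ccc(S(=O)(=O)c2cnc3c(F)cccc3c2-c2cccc(F)c2)cc1`: 3.03 mL/min
compound 2, `COc1ccc(S(=O)(=O)c2cnc3cc(F)ccc3c2-c2cccc(F)c2)cc1Cl`: 2.08 mL/min

Of the compounds shown here, two have so far been measured in an ADME assay on microsomes from liver (Homo sapiens) for metabolic stability, tested at 2.5 uM; on this read-out higher numbers stand for fast clearance and lower numbers for slow clearance. Compound 1 gives 3.03 mL/min, and compound 2 gives 2.08 mL/min; these two numbers lie within the usual scatter of repeated measurements of each other, so on this read-out compound 1 and compound 2 cannot be told apart. Compound 3, `COc1ccc(S(=O)(=O)c2cnc3c(F)cccc3c2-c2cccc(Cl)c2)cc1`, has not yet been measured. It differs from compound 1 in a single place: chloro in place of fluoro on an aromatic carbon. Within the data shown here, no measured pair in this set shows the effect of that change, so there is no measured step to lean on. The expectation for compound 3 in this assay is a step of a 1.1-fold higher number from compound 1 to compound 3 (0.04 log units; within the scatter) that stays within the scatter, with no clear direction. Compound 3 is therefore estimated at 3.3 mL/min, in a range from 1.6 mL/min to 6.5 mL/min.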

Compound 3, intrinsic clearance in a liver preparation (reported as CLH), per the amount of preparation that the assay uses: 2.75 mL/min
The estimate for compound 3 lay 1.2-fold (0.08 log units) above the measured number; low and high end bracket the measured number.
By their numbers in this assay, from the lowest: compounds 2, 3 and 1 (each within the scatter of the next).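

Among these compounds, the 3-fluorophenyl to 3-chlorophenyl change is the first single-place change that can be read in this assay and it gives a 1.1-fold lower number from compound 1 to compound 3 (0.04 log units; within the scatter). At this position, on an aromatic carbon meta to a large group, chloro in place of fluoro therefore leaves compound 1 and compound 3 indistinguishable on this read-out, though this one pair cannot show whether the same holds on another core. Nothing available bears on why the two compounds read alike.

The compounds shown leave open whether this position would tolerate a group of a different kind, such as a nitrile, an amine or a carboxylic acid, equally well. They also leave open how the read-out would respond to plain hydrogen at this position.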